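A few compounds are considered here, and "the series" means these few. Any claim that something is new, unique, unknown or untested is made for them only; others in the source may bear on it.

Measured so far in a functional assay on U-87MG ATCC cells (Homo sapiens) for antiproliferative activity; on this read-out lower numbers stand for stronger inhibition and higher numbers for weaker inhibition:

Compound 1 `Cc1c2c(n3c1CCCNC[C@H](C)Nc1cc-3ccc1C(N)=O)CC(C)(C)CC2=O`: 366 nM
Compound 2 `Cc1c2c(n3c1CCN(C)C[C@@H](C)[C@H](C)Nc1cc-3ccc1C(N)=O)CC(C)(C)CC2=O`: 49 nM

Of these two numbers, compound 2 at 49 nM is the lower, so it is the stronger inhibitor in this assay, and its gap to compound 1 lies beyond the usual scatter of repeated measurements. The next compound, compound 3 `CC[C@H](N)C(=O)N1CCc2c(C)c3c(n2-c2ccc(C(N)=O)c(c2)N[C@@H](C)[C@H](C)C1)CC(C)(C)CC3=O`, has not yet been measured. It starts from compound 2 and carries one change: (1-aminopropyl)carbonyl in place of methyl on an amine nitrogen in a ring. Among the measured compounds shown here, no measured pair shows this kind of swap, so the data offer no direct guide to its effect. For the measured compounds named here, the gap between the two measured compounds shows only that compounds of this kind can differ well beyond the scatter. A small move toward a higher number, meaning weaker inhibition, seems the likeliest outcome, though a larger move in either direction cannot be excluded. The expected change is a 1.8-fold higher number from compound 2 to compound 3 (0.26 log units; within the scatter). For compound 3 the estimated value is 90 nM, with an expected range from 20 nM to 400 nM.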

Compound 3, half-maximal inhibitory concentration: 45 nM
Estimate against measurement, compound 3: 2.0-fold (0.30 log units) above; the range from low to high includes it.
By their numbers in this assay, from the lowest: compounds 3 and 2 (each within the scatter of the next); then compound 1.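

In this assay, putting (1-aminopropyl)carbonyl in place of methyl on an amine nitrogen in a ring gives a 1.1-fold lower number from compound 2 to compound 3 (0.04 log units; within the scatter), so the two compounds cannot be told apart on this read-out. This nitrogen, which the earlier pair of compounds did not probe, therefore accepts a group of 6 heavy atoms in place of 1 heavy atom, along with a carbonyl, a hydrogen-bond donor and a defined stereocentre, while the number stays within the scatter. No separate measurement accompanies this pair that could account for the result.

A single swap at this nitrogen leaves open whether the same holds for other groups there, such as a plain acetyl, a longer acyl chain or a carboxylic acid. It also leaves open whether the amine and the stereocentre of the entering group matter, which the same chain without its amine, or the mirror-image form of the group, could help to settle.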